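The source may report more compounds than this note shows. Statements on the series, on what has been measured and on what is new or still open speak of the compounds shown alone.

Working notes on the series

Three compounds in this series have numbers in an assay for inhibition of protein kinase C theta type (Homo sapiens), read by TR-FRET, with stated times of 5 min and 60 min, in the presence of a further agent that is not named here (on this read-out lower numbers stand for stronger inhibition and higher numbers for weaker inhibition), so far. Compound 1 `N#Cc1ccc(N2CCNCC2c2ccccc2)nc1-n1c(=O)[nH]c2ncccc21` gives 6.3 nM in this assay. Compound 2 `CCOc1ccnc2[nH]c(=O)n(-c3nc(N4CCCNCC4)ccc3Cl)c12` gives 0.086 nM in this assay, the lowest of the two numbers shown; the nearest neighbour on the read-out is compound 1, whose number is higher by a margin well beyond the scatter of repeated measurements. For compound 3 `O=c1[nH]c2ncccc2n1-c1nc(N2CCCC(C(O)C3CC3)C2)ccc1F` the result in this assay is only a limit, > 1000 nM, and not a number (the limit of > 1000 nM in this assay, at which 1 of the 3 values shown sits).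

Among the measured compounds shown here, no pair of measured compounds differs in a single place, so no measured step exists to lean on. The next compound, compound 4 `O=c1[nH]c2ncccc2n1-c1nc(N2CCCNCC2)ccc1Cl`, differs from compound 2 in one place: hydrogen in place of ethoxy on an aromatic carbon of the shared core. Compound 1, also lacking a substituent at that carbon but differing elsewhere, and compound 3, whose value is a limit, give no direct reading on this change.

The loss of the ethoxy group is expected to cost potency in this assay, with a step of a 7.0-fold higher number from compound 2 to compound 4 (0.84 log units; beyond the scatter) that would lie beyond the scatter. Compound 4 is therefore estimated at 0.6 nM in this assay, within a range from 0.1 nM to 5 nM.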

Compound 4, half-maximal inhibitory concentration: 18 nM
Estimate against measurement, compound 4: 30-fold (1.48 log units) below; measured number above the stated range.
By their numbers in this assay, from the lowest: compound 2; then compound 1; then compound 4. At a limit, above all of these: compound 3.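

The ethoxy group on this aromatic carbon, ortho to a fused ring and opposite the ring nitrogen, turns out to count heavily in this assay: replacing it with hydrogen gives a 210-fold higher number from compound 2 to compound 4 (2.32 log units; beyond the scatter). Among the compounds shown here, this is the first measured single-place step, so the position now has a direct reading, with the rest of compound 2 unchanged and a step well beyond the usual scatter of the read-out. The low number of compound 2 therefore depends on the ethoxy group being present at this carbon, yet no measured property in the data bears on why the step is so large.

From the compounds shown here alone, what remains open is how the effect depends on the group itself: with only ethoxy and hydrogen compared at this carbon, a methoxy group, a longer alkoxy chain or an amine could each fall anywhere relative to these two compounds. Going by these compounds, it is also open whether a step of this size would carry over to other compounds, such as compound 1, whose other differences keep it from being compared directly with either compound here.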